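Bromo for Methoxy on the Shared Core

This account rests on a few compounds, and the source may have more. Where it says the series, first, only, none or still open, it means among the compounds named here.

compound 1 `COc1ccc(Cn2cc(/C=N\NC(=O)c3c[nH]c4ccccc34)c3cc(OC)ccc32)cc1`: 15000 nM
compound 2 `COc1ccc2c(c1)c(/C=N\NC(=O)c1c[nH]c3ccccc13)cn2Cc1ccc(Cl)cc1`: 8700 nM

In a functional assay on MCF7 cells (Homo sapiens) for cytotoxicity (on this read-out lower numbers stand for stronger inhibition and higher numbers for weaker inhibition), compound 2 gives 8700 nM, while compound 1 gives 15000 nM, and the pair is separated only by a 1.7-fold lower number from compound 1 to compound 2 (0.24 log units; within the scatter), within the scatter. Compound 3 `O=C(N/N=C\c1cn(Cc2ccc(Cl)cc2)c2ccc(Br)cc12)c1c[nH]c2ccccc12` differs from compound 2 by bromo in place of methoxy on an aromatic carbon. Within the data shown here, the one measured step, a 1.7-fold lower number from compound 1 to compound 2 (0.24 log units; within the scatter), also exchanged a methoxy for a halogen and barely moved the number. Compound 3 is therefore expected to show a step of a 1.2-fold lower number from compound 2 to compound 3 (0.09 log units; within the scatter), nothing beyond the scatter. The estimate for compound 3 is 7000 nM, with a range from 2500 nM to 20000 nM.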

Compound 3, half-maximal inhibitory concentration: 3200 nM
Compound 3: the middle estimate sits 2.2-fold (0.34 log units) above what was measured; measured number inside the range.
By their numbers in this assay, from the lowest: compound 3; then compounds 2 and 1 (each within the scatter of the next).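

In this assay, among these compounds, bromo in place of methoxy on the shared core gives a 2.7-fold lower number from compound 2 to compound 3 (0.43 log units; beyond the scatter), the first step here beyond the scatter, though a modest one. The earlier exchange, chloro in place of methoxy on a different aromatic carbon, stayed within the scatter, but the two steps differ in both place and halogen, so neither factor can be credited alone. No available evidence explains the difference.

From the compounds shown here alone, whether the change reflects bromo itself or the departure of methoxy remains open. Going by these compounds, how chloro or an amine would behave on the same carbon also remains open.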